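Replacing 4-carboxyphenyl with thiophen-2-yl

The source may report more compounds than this note shows. Statements on the series, on what has been measured and on what is new or still open speak of the compounds shown alone.

Of the compounds shown here, two sharing one core have been tested so far in a functional assay on HeLa cells (Homo sapiens) for inhibition, with a stated time of 72 h; on this read-out lower numbers stand for an effect already at smaller amounts and higher numbers for an effect only at larger amounts of compound. There, compound 1 `COc1cc(CNCCSc2nnnn2C)ccc1OCc1ccc(Cl)nc1` gives 86000 nM, a single number that sets the only reference point. Compound 2 `COc1cc(CNCc2ccc(C(=O)O)cc2)ccc1OCc1ccc(Cl)nc1` yields no number at all: its entry reads "nd(insoluble)" (no result reported). It therefore has no place on the scale, and nothing can be said about how it compares with compound 1.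

The next compound to be tested is compound 3 `COc1cc(CNCc2cccs2)ccc1OCc1ccc(Cl)nc1`. It keeps the shared core and carries thiophen-2-yl in place of 4-carboxyphenyl on a saturated chain carbon bound to an amine nitrogen.

Within the data shown here, no measured step exists to show how much such a swap matters. Among the measured compounds shown here, compound 2 offers no number, so the only anchor is compound 1 at 86000 nM. The expectation in this assay is a modest step from that anchor towards lower numbers, little beyond the usual scatter of repeated measurements. The estimate for compound 3 is 40000 nM, with an expected range from 10000 nM to 120000 nM.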

Compound 3, half-maximal effective concentration: 96000 nM
Compound 3: the middle estimate sits 2.4-fold (0.38 log units) below what was measured, and the stated range covers the measured number.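

The new number gives this position its first readable step: in this assay the change from ((1-methyl-1H-tetrazol-5-yl)sulfanyl)methyl to thiophen-2-yl, on a saturated chain carbon bound to an amine nitrogen, reads as a 1.1-fold higher number from compound 1 to compound 3 (0.05 log units; within the scatter) and so cannot be told apart from repeat-to-repeat variation. Two groups with quite different names and atoms, one of them a single five-membered aromatic ring with one sulfur, therefore give values within the usual scatter of each other on this read-out. From the compounds shown here alone, compound 2 has no number, so the step from 4-carboxyphenyl to thiophen-2-yl, the swap this piece set out to examine, cannot be read, and what the carboxyphenyl group does at this place stays unknown.

No supporting data are available to explain why these two groups give such similar values. Still open, going by these compounds, is whether a plain phenyl ring, a furan-2-yl ring, a pyridin-3-yl ring or a longer alkyl chain at this same place would shift the number by more than the scatter, or whether the values would stay where these two compounds sit.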